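The compounds below may be only part of what the source reports. "The series", "measured", "known", "first", "only" and "open" are said of these compounds alone.

Compound 1, `CCCC(O)CC(=O)O[C@H](CC=C(C)C)C1=CC(=O)c2c(O)ccc(O)c2C1=O`, was tested in a functional assay on DU-145 cells (Homo sapiens) for cytotoxicity, read by MTT assay; a higher number here means a weaker inhibitor, a lower number a stronger inhibitor. For compound 1 the assay reports only a limit, > 100000 nM, and not a number. Two companions share its core but carry a 2-acetoxybutyl or a 2-acetoxypropyl group in place of the (2-hydroxypentyl)carbonyl: compound 2, `CCC(CO[C@H](CC=C(C)C)C1=CC(=O)c2c(O)ccc(O)c2C1=O)OC(C)=O`, and compound 3, `CC(=O)OC(C)CO[C@H](CC=C(C)C)C1=CC(=O)c2c(O)ccc(O)c2C1=O`. In this assay compound 2 gives 25400 nM, and compound 3 gives 16600 nM. The steps of an at least 3.9-fold lower number from compound 1 to compound 2 (0.59 log units; beyond the scatter) and an at least 6.0-fold lower number from compound 1 to compound 3 (0.77 log units; beyond the scatter) are read against a limit (the limit of > 100000 nM in this assay, at which 1 of the 3 values shown sits), so only their floors are known, while the step of a 1.5-fold lower number from compound 2 to compound 3 (0.18 log units; within the scatter) is small. Compound 4, `CCCCCCC(C)(O)CC(=O)O[C@H](CC=C(C)C)C1=CC(=O)c2c(O)ccc(O)c2C1=O`, keeps the ester of compound 1 and changes only the hydroxy-bearing chain: 1-hydroxy-1-methylheptyl in place of 1-hydroxybutyl on a saturated chain carbon bound to a carbonyl carbon. Among the compounds with values here, no measured step alters this chain while keeping the ester, so the measured steps say nothing directly about compound 4; they show only that compounds 2 and 3 reach measurable numbers once the ester chain is swapped. Because compound 1 sits at the limit (the limit of > 100000 nM in this assay, at which 1 of the 3 values shown sits), compound 4 is expected to show a step of uncertain size, an at least 1.2-fold lower number from compound 1 to compound 4 (0.09 log units; that floor lies within the scatter), with a real chance that again only a limit is reported. The estimate for compound 4 in this assay is 80000 nM, ranging from 20000 nM to 300000 nM.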

Compound 4, half-maximal inhibitory concentration: > 100000 nM
Compound 4: no number, only a limit; the forecaster's own chance of this, stated with the estimate: 55%; at least 1.2-fold (0.09 log units) between middle value and limit.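

In this assay compound 1 and compound 4 both end at a limit and not at a number, so no step between them can be read: the limit of > 100000 nM in this assay, at which 2 of the 4 values shown sit.

The compounds shown leave open whether 1-hydroxy-1-methylheptyl in place of 1-hydroxybutyl changes the result at all, and how far beyond the limit either compound lies.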